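Side-chain change from compound 3 to compound 4

The compounds below may be only part of what the source reports. "The series", "measured", "known", "first", "only" and "open" are said of these compounds alone.

Values in a functional assay on P388 cells (Mus musculus) for cytotoxicity; a lower number here means a stronger inhibitor, a higher number a weaker inhibitor:
- compound 1 `COC(=O)CC[C@@H]1NC(=O)[C@@H](C)NC(=O)[C@@H]2Cc3ccc(OC)c(c3)Oc3ccc(cc3)C[C@@H](C(=O)N2C)N(C)C(=O)[C@H](C)NC(=O)[C@H](Cc2ccc(OC)cc2)N(C)C1=O`: 58.9 nM
- compound 2 `COc1ccc(C[C@H]2C(=O)N[C@@H](C)C(=O)N(C)[C@H]3Cc4ccc(cc4)Oc4cc(ccc4OC)C[C@@H](C(=O)N[C@H](C)C(=O)N[C@@H](CSC(C)=O)C(=O)N2C)N(C)C3=O)cc1`: 9.77 nM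
- compound 3 `COc1ccc(C[C@H]2C(=O)N[C@@H](C)C(=O)N(C)[C@H]3Cc4ccc(cc4)Oc4cc(ccc4OC)C[C@@H](C(=O)N[C@H](C)C(=O)N[C@@H](CS)C(=O)N2C)N(C)C3=O)cc1`: 363 nM

Compound 3 has the highest number of the three and is the weakest measured member, with both gaps beyond the scatter. Compound 4 `COc1ccc(C[C@H]2C(=O)N[C@@H](C)C(=O)N(C)[C@H]3Cc4ccc(cc4)Oc4cc(ccc4OC)C[C@@H](C(=O)N[C@H](C)C(=O)N[C@@H](CCCN=[N+]=[N-])C(=O)N2C)N(C)C3=O)cc1` carries 2-azidoethyl in place of sulfanyl on a saturated chain carbon bound to a saturated ring carbon.

Among the measured compounds shown here, no measured step involves an azide, so the evidence is indirect. For the measured compounds named here, two steps bear on this change, as each ends at the free sulfanyl of compound 3: a 6.2-fold higher number from compound 1 to compound 3 (0.79 log units; beyond the scatter) and a 37-fold higher number from compound 2 to compound 3 (1.57 log units; beyond the scatter). Going by the values given here, both compounds without that group have lower numbers, but this rests on only three compounds. A modest step to a lower number in this assay is therefore expected, closer in size to the first of these steps.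

For compound 4 the expected value is 70 nM, with an estimated range of 15 nM to 300 nM. The estimated change is a 5.2-fold lower number from compound 3 to compound 4 (0.71 log units; beyond the scatter).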

Compound 4, half-maximal inhibitory concentration: 35.5 nM
Beside the measured number, compound 4's estimate is 2.0-fold (0.29 log units) above it, and the stated range covers the measured number.
By their numbers in this assay, from the lowest: compound 2; then compounds 4 and 1 (each within the scatter of the next); then compound 3.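

In this assay, sulfur is not needed at this position for a low number: a 10-fold lower number from compound 3 to compound 4 (1.01 log units; beyond the scatter), and 2-azidoethyl has no sulfur and no hydrogen-bond donor, leaving the free sulfanyl of compound 3 as the weakest of the four. The azide side chain still falls short of the acetylsulfanyl group, a 3.6-fold higher number from compound 2 to compound 4 (0.56 log units; beyond the scatter), while no separation from the methoxycarbonyl side chain appears, a 1.7-fold lower number from compound 1 to compound 4 (0.22 log units; within the scatter). Nothing measured here accounts for these differences.

On these data alone, whether the gain over sulfanyl belongs to the azide or to the longer chain stays open; a primary amine or a plain propyl chain at this place would separate the two. Also open, as far as these compounds go, is whether compound 2 owes its position to the sulfur or to the acetyl group, which a propanoylsulfanyl or acetoxy group could test.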